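A 3-Chlorophenyl Swap on the Amide-Type Nitrogen

A few compounds are considered here, and "the series" means these few. Any claim that something is new, unique, unknown or untested is made for them only; others in the source may bear on it.

In an ADME assay on MT4 cells (Homo sapiens) for cytotoxicity, read by MTT assay, with a stated time of 5 days (on this read-out higher numbers stand for lower toxicity in this test and lower numbers for higher toxicity in this test), compound 1 (`COc1cc2nc(Nc3ccc(C#N)cc3)nc(Nc3c(C)cc(/C=C/C#N)cc3F)c2cc1OC`) gives only a limit of > 52000 nM and no exact number. Compound 2 (`COc1cc2nc(SCC(=O)Nc3ccc(C(F)(F)F)cc3)nc(Nc3c(C)cc(/C=C/C#N)cc3C)c2cc1OC`) also gives only a limit of > 211000 nM in this test. Compound 3 (`COc1cc2nc([S+]([O-])CC(=O)Nc3ccccc3[N+](=O)[O-])nc(Nc3c(Cl)cc(/C=C/C#N)cc3Cl)c2cc1OC`) likewise has only a limit of > 199000 nM and so holds no exact place among these values.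

Compound 4 (`COc1cc2nc([S+]([O-])CC(=O)Nc3cccc(Cl)c3)nc(Nc3c(Cl)cc(/C=C/C#N)cc3Cl)c2cc1OC`) carries 3-chlorophenyl in place of 2-nitrophenyl on an amide-type nitrogen. For the measured compounds named here, no measured step bears on this change, so no shift beyond the scatter is expected in this assay. That expectation rests on compound 3 and its limit (> 199000 nM) alone. The expected step is a step that the limit leaves unreadable from compound 3 to compound 4 in this estimate. Compound 4 is estimated at 200000 nM with an expected range of 70000 nM to 300000 nM in the same test.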

Compound 4, half-maximal cytotoxic concentration: 68900 nM
Estimate against measurement, compound 4: 2.9-fold (0.46 log units) above; the whole stated range lies above it.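

In this assay, 3-chlorophenyl in place of 2-nitrophenyl on the amide-type nitrogen gives an at least 2.8-fold lower number from compound 3 to compound 4 (0.46 log units; beyond the scatter), so this position can change the read-out, towards higher toxicity in this test. For the compounds shown here, compound 4 is also the first compound here with an exact value rather than a limit. The true size of the step stays unknown because compound 3 gives only a limit: the limit of > 199000 nM in this assay, at which 1 of the 4 values shown sits.

One swap cannot separate the loss of 2-nitrophenyl from the arrival of 3-chlorophenyl. As far as these compounds go, how a plain phenyl or a 3-aminophenyl on the same nitrogen would read in this assay remains open.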